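Swapping Fluoro for Chloro: an Expectation for Compound 4

A few compounds are considered here, and "the series" means these few. Any claim that something is new, unique, unknown or untested is made for them only; others in the source may bear on it.

In a functional assay on NALM-6 cells (Homo sapiens) for cytotoxicity, read by luminescence and CellTiter-Glo, with a stated time of 3 days (on this read-out higher numbers stand for weaker inhibition and lower numbers for stronger inhibition), the measured compounds are:
compound 1 `O=C(Nc1ccc(C(F)(F)F)cc1)c1cc(Cl)ccc1O` gives 1210 nM
compound 2 `O=C(Nc1ccc(OC(F)(F)F)c(Cl)c1)c1cc(F)ccc1O` gives 1000 nM
compound 3 `O=C(Nc1ccc(C(F)(F)F)cc1)c1cc(F)ccc1O` gives 2090 nM

Compound 1 and compound 3 differ in one place: chloro in place of fluoro on an aromatic carbon. In this assay that single change produced a 1.7-fold lower number from compound 3 to compound 1 (0.24 log units; within the scatter), a step too small to count as a real difference. Compound 2 and compound 3 differ in more than one place, so the difference between the two cores is not broken down here; what the values show is that compound 2 stands within the scatter of compound 1 and beyond it from compound 3.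

Compound 4 `O=C(Nc1ccc(OC(F)(F)F)c(Cl)c1)c1cc(Cl)ccc1O` is not yet measured. It arises from compound 2 by the same change: chloro in place of fluoro on an aromatic carbon. The place is described in the same words as for the measured pair, so this is the same change, seen here twice in all.

In this assay, going by the values given here, the step from compound 2 to compound 4 is expected to be about a 1.5-fold lower number from compound 2 to compound 4 (0.19 log units; within the scatter), resting on the one measured precedent because the measured pair gave a 1.7-fold lower number from compound 3 to compound 1 (0.24 log units; within the scatter). Compound 4 is therefore estimated at 650 nM, with a likely range from 300 nM to 1400 nM.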

Compound 4, half-maximal inhibitory concentration: 1050 nM
For compound 4 the middle estimate is 1.6-fold (0.21 log units) below the measured one; the range from low to high includes it.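

In this assay, putting chloro where fluoro stood gave a 1.1-fold higher number from compound 2 to compound 4 (0.02 log units; within the scatter), a step too small to count as a real difference. Set side by side, the two cases of this change do not differ by more than repeated measurements of this kind can account for: the same change on two cores in this assay, a 1.7-fold lower number (0.24 log units; within the scatter) from compound 3 to compound 1 and a 1.1-fold higher number (0.02 log units; within the scatter) from compound 2 to compound 4, 1.8-fold (0.26 log units) apart, within the scatter of two such steps. So on both cores the swap left the number within the scatter, which is consistent with the change carrying over from one core to the other, but two small steps show only that no clear effect appeared on these cores, not that the swap is without effect on every core in the series or that a small real effect is absent.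

The compounds shown hold only fluoro or chloro in this place, which leaves open how a methyl group, a methoxy group or a nitrile would fare there. On these data alone, they also keep the hydroxy group throughout, so what an amine in its place would do remains open.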